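The compounds below may be only part of what the source reports. "The series", "measured", "known", "first", "only" and "open" are said of these compounds alone.

Compounds measured so far in a functional assay on MDA-MB-231 cells (Homo sapiens) for antiproliferative activity, with a stated time of 4 days (on this read-out higher numbers stand for weaker inhibition and lower numbers for stronger inhibition), are:

Compound 1 (`COc1ccc(-c2[nH]c3ccc(OC)cc3c2C=O)cc1`) gives 260 nM in this test
Compound 2 (`COc1ccc(-c2[nH]c3ccc(CC(C)C)cc3c2C=O)cc1`) gives 72 nM in this test

Of these two numbers, compound 2 holds the lower, and so it is the stronger inhibitor of the pair in this assay on the evidence so far. Compound 3 (`CCCCCc1ccc2[nH]c(-c3ccc(OC)cc3)c(C=O)c2c1`) has not yet been measured. It differs from compound 2 by a small change in the chain: butyl in place of isopropyl on a saturated chain carbon bound to an aromatic carbon and, cut one bond further out, the same difference reads isobutyl to pentyl.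

Going by the values given here, only one measured step bears on this change, and only indirectly. That modest step, a 3.6-fold lower number from compound 1 to compound 2 (0.56 log units; beyond the scatter) (beyond the scatter), replaced methoxy with isobutyl on an aromatic carbon. Among the compounds with values here, it shows that the number can move when the group at that place changes, but no measured pair compares one saturated chain with another. Compound 3 keeps a saturated chain there, so the expected change is smaller than that step, and none beyond the scatter is expected. The estimate therefore amounts to a 1.3-fold higher number from compound 2 to compound 3 (0.10 log units; within the scatter) as the expected step. For compound 3 the estimated value is 90 nM (expected range 30 nM to 270 nM).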

Compound 3, half-maximal inhibitory concentration: 5.5 nM
Compound 3: the middle estimate sits 16-fold (1.21 log units) above what was measured; the measured number lies below the stated range.
By their numbers in this assay, from the lowest: compound 3; then compound 2; then compound 1.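

In this assay, going by these compounds alone, the earlier compounds showed only that replacing methoxy with a saturated chain on an aromatic carbon could move the number. Compound 3 shows that the choice between two saturated chains at this place can also matter: going from isobutyl to pentyl gives a 13-fold lower number from compound 2 to compound 3 (1.12 log units; beyond the scatter), a large step where the earlier one was modest, so this small change in the chain is not a neutral one. Measured against the methoxy compound, pentyl gives a 47-fold lower number from compound 1 to compound 3 (1.67 log units; beyond the scatter), and nothing shown accounts for the size of either step.

The compounds shown do not separate the length of the chain from its branching, as isobutyl and pentyl differ in both, and an unbranched butyl or a branched chain of the same size as pentyl would be needed to tell the two apart. They also leave open whether the trend continues or reverses with a longer chain such as hexyl or octyl, and how the number responds to a chain ending in an amine or a carboxylic acid.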